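The source may hold more compounds than are shown below. What is called first, only, known or untested is meant among the compounds shown, and "the series" means these compounds.

Measured compounds:
compound 1, `COc1ccc(-c2cn(C[C@H]3c4c(ccc(OS(=O)(=O)c5ccc(C)cc5)c4C)[C@@H]4CC[C@@]5(C)C[C@]43CC5=O)nn2)cc1`, which in a functional assay on A549 cells (Homo sapiens) for cytotoxicity, read by MTT assay, with a stated time of 4 days (a higher number here means a weaker inhibitor, a lower number a stronger inhibitor), gives > 20000 nM, a limit of the assay and not a number;
compound 2, `Cc1ccc(-c2cn(C[C@H]3c4c(ccc(O)c4C)[C@@H]4CC[C@@]5(C)C[C@]43CC5=O)nn2)cc1`, which in this assay gives > 20000 nM, again a limit;
compound 3, `Cc1ccc(-c2cn(C[C@H]3c4c(ccc(OS(=O)(=O)c5ccc(C)cc5)c4C)[C@@H]4CC[C@@]5(C)C[C@]43CC5=O)nn2)cc1`, which in this assay gives > 20000 nM, again a limit.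

Among the measured compounds shown here, all three measured compounds sit at the limit of > 20000 nM in this assay, at which 3 of the 3 values shown sit, so no step among them can be read. The change from compound 3 to compound 1 is methoxy in place of methyl on an aromatic carbon, and it made a step that the two limits leave unreadable from compound 3 to compound 1. The change from compound 3 to compound 2 is hydrogen in place of (4-methylphenyl)sulfonyl on an oxygen on an aromatic ring, and it made a step that the two limits leave unreadable from compound 2 to compound 3 in the other direction.

Compound 4, `COc1ccc(-c2cn(C[C@H]3c4c(ccc(O)c4C)[C@@H]4CC[C@@]5(C)C[C@]43CC5=O)nn2)cc1`, remains to be measured in this assay. It differs from compound 2 by methoxy in place of methyl on an aromatic carbon, the same change as from compound 3 to compound 1, at the same place. Since compound 3 and compound 1 both sit at the limit of > 20000 nM in this assay, at which 3 of the 3 values shown sit, the step is expected to be a step that the limit leaves unreadable from compound 2 to compound 4. Compound 4 is therefore estimated at 30000 nM, with a range of 10000 nM to 100000 nM, and most likely reported only as a limit.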

Compound 4, half-maximal inhibitory concentration: > 20000 nM
Compound 4 gave a limit, no number; the forecaster's own chance of this, stated with the estimate: 85%; the middle value lies beyond the limit too.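

Among the compounds shown here, compound 4 gives only a limit in this assay, as do compound 1 and compound 2, so no step from either of them to compound 4 can be read: the limit of > 20000 nM in this assay, at which 4 of the 4 values shown sit.

The compounds shown leave open what number any of them would give in this assay, and whether 4-methylphenyl to 4-methoxyphenyl or the (4-methylphenyl)sulfonyl on the oxygen changes it at all.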